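The source may report more compounds than this note shows. Statements on the series, on what has been measured and on what is new or still open speak of the compounds shown alone.

Compound 3 `Cc1cc(-c2ccccc2NCC2=NCCN2)on1` is one of three close relatives in which a small five-membered ring hangs from the shared core. Among the measured compounds shown here, in a functional assay for activation of Alpha-1B adrenergic receptor (Homo sapiens), read by calcium flux (a lower number here means that less compound is needed, a higher number that more compound is needed for the effect), compound 3 gives 95.5 nM, one of only two readable numbers in this set. Compound 1 `Cc1nc(-c2ccccc2NCC2=NCCN2)cs1` gives 69.2 nM in this assay, and the step of a 1.4-fold higher number from compound 1 to compound 3 (0.14 log units; within the scatter) is within the scatter. Compound 2 `Cc1nc(-c2ccccc2NCC2=NCCN2)co1` gives only a limit, < 5020 nM, in this assay. Because of the limit of < 5020 nM in this assay, at which 1 of the 3 values shown sits, the steps a step that the limit leaves unreadable from compound 1 to compound 2 and a step that the limit leaves unreadable from compound 2 to compound 3 cannot be sized. Compound 4 `Cc1ccsc1-c1ccccc1NCC1=NCCN1` has not yet been measured; it differs from compound 3 by 3-methylthiophen-2-yl in place of 3-methyl-1,2-oxazol-5-yl on an aromatic carbon. For the measured compounds named here, the single readable step, a 1.4-fold higher number from compound 1 to compound 3 (0.14 log units; within the scatter), stayed within the scatter, so a ring swap of this kind is expected to shift the number little, amounting to a 1.5-fold lower number from compound 3 to compound 4 (0.17 log units; within the scatter). Compound 4 is therefore estimated at 65 nM, with a likely range from 20 nM to 220 nM.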

Compound 4, half-maximal effective concentration: 112 nM
For compound 4 the middle estimate is 1.7-fold (0.24 log units) below the measured one, within the range that was stated.
By their numbers in this assay, from the lowest: compounds 1, 3 and 4 (each within the scatter of the next).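

In this assay, 3-methylthiophen-2-yl on this aromatic carbon gives a 1.2-fold higher number from compound 3 to compound 4 (0.07 log units; within the scatter), and against the thiazole it gives a 1.6-fold higher number from compound 1 to compound 4 (0.21 log units; within the scatter). A five-membered aromatic ring with 1 hetero atom, sulfur, therefore fits here as well as the rings with 2 hetero atoms in compound 1 and compound 3. Compound 2 may go against this pattern, but its steps cannot be read because it gives only a limit: the limit of < 5020 nM in this assay, at which 1 of the 4 values shown sits.

On these data alone, what an amine or a carboxylic acid would do at this position stays open. So does the effect of a larger six-membered ring such as pyridine.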